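This account rests on a few compounds, and the source may have more. Where it says the series, first, only, none or still open, it means among the compounds named here.

In a functional assay on NT2 cells (Homo sapiens) for inhibition (on this read-out lower numbers stand for stronger inhibition and higher numbers for weaker inhibition), the measured compounds stand as follows:
- compound 1 `CCCCCCN(C)CNCC(=O)[C@H](CC(=O)O)NC(=O)C(CC)n1cc(CC)nc(NCc2nonc2C)c1=O` gives 0.078 nM
- compound 2 `CCC(C(=O)N[C@@H](CC(=O)O)C(=O)CNCN1CCC(Cc2ccccc2)CC1)n1ccnc(NCc2nonc2C)c1=O` gives 1.62 nM
- compound 3 `CCC(C(=O)N[C@@H](CC(=O)O)C(=O)CSCc1ccccc1)n1ccnc(NCC2COc3ccccc3O2)c1=O` gives 30 nM

Compound 3 has the highest number of the three, which makes it the weakest inhibitor, well beyond the scatter. Compound 4 `CCC(C(=O)N[C@@H](CC(=O)O)C(=O)CSCc1ccccc1)n1ccnc(NCc2cc(C)no2)c1=O` carries 3-methyl-1,2-oxazol-5-yl in place of 2,3-dihydro-1,4-benzodioxin-2-yl on a saturated chain carbon bound to a nitrogen on an aromatic ring, counted as 3-methyl-1,2-oxazol-5-yl in place of 2,3-dihydro-1,4-benzodioxin-2-yl on a saturated chain carbon bound to a nitrogen on an aromatic ring in full. Among the compounds with values here, no measured pair shows this change alone. Compound 1 and compound 2 have lower numbers but differ from compound 3 in more than one place, so they offer only a loose hint of a modest move towards stronger inhibition in this assay. The expected change is a 3.0-fold lower number from compound 3 to compound 4 (0.48 log units; beyond the scatter), an estimate with wide uncertainty. For compound 4 the estimated value is 10 nM, with an expected range from 2 nM to 40 nM.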

Compound 4, half-maximal inhibitory concentration: 6.41 nM
Estimate against measurement, compound 4: 1.6-fold (0.19 log units) above; the measured number falls inside the stated range.
By their numbers in this assay, from the lowest: compound 1; then compound 2; then compound 4; then compound 3.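

Within the data shown here, this pair gives the first direct reading at this position. On a saturated chain carbon bound to a nitrogen on an aromatic ring, 3-methyl-1,2-oxazol-5-yl in place of 2,3-dihydro-1,4-benzodioxin-2-yl gives, in this assay, a 4.7-fold lower number from compound 3 to compound 4 (0.67 log units; beyond the scatter), so the group with fewer heavy atoms serves better here than the one it replaces. No measurement on hand explains this gain. From the compounds shown here alone, it remains open how a pyridine ring or a simple amine at this place would compare, and whether the same swap gives a similar step with the rest of the molecule changed.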